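The compounds below may be only part of what the source reports. "The series", "measured", "known", "first", "only" and "open" are said of these compounds alone.

Working notes on the series. In a functional assay on MCF7 cells (Homo sapiens) for cytotoxicity, read by MTT assay, with a stated time of 48 h (a higher number here means a weaker inhibitor, a lower number a stronger inhibitor), compound 1 `C/C(=N/NC(=S)Nc1ccccc1F)c1ccccn1` gives 0.39 nM, compound 2 `C/C(=N\NC(=S)Nc1ccccc1Cl)c1ccccn1` gives 0.16 nM and compound 3 `C/C(=N/NC(=S)Nc1ccccc1I)c1ccccn1` gives 4.1 nM. Compound 3 therefore has the highest number of the three, beyond the scatter from both others.

Compound 4 `C/C(=N/NC(=S)Nc1ccccc1Cl)c1ccccn1` differs from compound 3 as follows: chloro in place of iodo on an aromatic carbon. The one measured step that bears directly on this change is an 11-fold higher number from compound 1 to compound 3 (1.02 log units; beyond the scatter), a large step with iodo in place of fluoro, and compound 4 shares its double-bond geometry with both of these compounds. Read in reverse, that step points to a lower number once iodo leaves. Among the measured compounds shown here, compound 2 also carries chloro, at 0.16 nM, but its double-bond geometry is opposite, and no measured step isolates that difference, so it offers only loose support.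

In this assay, a large move to a lower number is expected, with the estimated step being a 9.1-fold lower number from compound 3 to compound 4 (0.96 log units; beyond the scatter). The estimate for compound 4 is 0.45 nM, with an expected range of 0.13 nM to 1.6 nM.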

Compound 4, half-maximal inhibitory concentration: 0.16 nM
The estimate for compound 4 lay 2.8-fold (0.45 log units) above the measured number; the range from low to high includes it.
By their numbers in this assay, from the lowest: compounds 2 and 4 (each within the scatter of the next); then compound 1; then compound 3.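

With the double-bond geometry held fixed, chloro in place of iodo gives a 26-fold lower number from compound 3 to compound 4 (1.41 log units; beyond the scatter) in this assay, and chloro in place of fluoro gives a 2.4-fold lower number from compound 1 to compound 4 (0.39 log units; beyond the scatter). Among these three halogens, chloro therefore carries the lowest number at this position, and the numbers do not run in the order fluoro, chloro, iodo. The double-bond geometry, which could not be separated from the halogen change before, shows no change at the digits printed from compound 2 to compound 4 (within the scatter), so in the chloro pair the drawn configuration makes no difference beyond the scatter: the fact that compounds 2 and 4 differ only in the configuration as drawn

On these data alone, whether the two geometries also match with fluoro or iodo remains open. So does how bromo, methyl or methoxy at this position would compare with chloro.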